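The source may report more compounds than this note shows. Statements on the series, on what has been measured and on what is new or still open speak of the compounds shown alone.

Going by the values given here, in a functional assay on MCF7 cells (Homo sapiens) for cytotoxicity, read by MTT assay, with a stated time of 72 h (on this read-out higher numbers stand for weaker inhibition and lower numbers for stronger inhibition), compound 1 (`O=C1c2c[n+]([O-])c3ccccc3c2C(=O)c2c1c1ccccc1n2CCCCn1ccnc1`) gives 130 nM, the lowest of the three numbers measured so far. Compound 2 (`CC1(C)OCC(Cn2cc(Cn3c4c(c5ccccc53)C(=O)c3c[n+]([O-])c5ccccc5c3C4=O)nn2)O1`) gives 290 nM, and compound 3 (`CC1(C)OC[C@H](Cn2cc(Cn3c4c(c5ccccc53)C(=O)c3c[n+]([O-])c5ccccc5c3C4=O)nn2)O1`) gives 530 nM. Both stand clearly above compound 1, and both carry a different side chain on the shared core.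

Compound 4 (`CCCN1CCN(CCCCn2c3c(c4ccccc42)C(=O)c2c[n+]([O-])c4ccccc4c2C3=O)CC1`) has not yet been measured. It differs from compound 1 by a single exchange: 4-propylpiperazin-1-yl in place of 1H-imidazol-1-yl on a saturated chain carbon, four bonds along the chain from an aromatic nitrogen. The 4-propylpiperazin-1-yl group takes the place of 1H-imidazol-1-yl on a saturated chain carbon, four bonds along the chain from an aromatic nitrogen.

Among the compounds with values here, the only measured step between closely matched compounds is a 1.8-fold higher number from compound 2 to compound 3 (0.26 log units; within the scatter). It concerns the fact that one of compounds 2 and 3 is drawn with a defined configuration and the other without, at the place where they differ and involves neither of the two groups exchanged here, so it gives no direct guide to their exchange. The nearest indication is the spread of values across different side chains, which reaches compound 3 at 530 nM. That spread argues for a wide range but gives no direction.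

The expected step is a 1.5-fold higher number from compound 1 to compound 4 (0.19 log units; within the scatter), and it is estimated to remain within the scatter. The estimate for compound 4 is 200 nM, with an expected range from 60 nM to 700 nM.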

Compound 4, half-maximal inhibitory concentration: 1280 nM
For compound 4 the middle estimate is 6.4-fold (0.81 log units) below the measured one; the whole stated range lies below it.
By their numbers in this assay, from the lowest: compound 1; then compounds 2 and 3 (each within the scatter of the next); then compound 4.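

In this assay, 4-propylpiperazin-1-yl in place of 1H-imidazol-1-yl on a saturated chain carbon, four bonds along the chain from an aromatic nitrogen, brings a 9.8-fold higher number from compound 1 to compound 4 (0.99 log units; beyond the scatter), the only step shown between compounds differing in one place that lies beyond the scatter. Going by these compounds alone, it shows that the number responds to the group at this position, which the earlier compounds could not show: their one matched step concerned a drawn configuration, and their side chains otherwise differed from that of compound 1 in more than a single group. The exchange replaces a five-membered aromatic ring with a larger six-membered non-aromatic ring that also carries a propyl group, and nothing measured here bears on why the number rises.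

The compounds shown leave open whether the rise follows the piperazine ring itself or its propyl group, a question that 4-methylpiperazin-1-yl, an unsubstituted piperazin-1-yl or morpholin-4-yl at the same place would address. They also leave open how either group would behave on a shorter or a longer chain, and whether a simple dimethylamino group would stay nearer to compound 1 or to compound 4.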